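A few compounds are considered here, and "the series" means these few. Any claim that something is new, unique, unknown or untested is made for them only; others in the source may bear on it.

Measured in a functional assay on HeLa cells (Homo sapiens) for inhibition, read by sulforhodamine B assay, with a stated time of 74 h; on this read-out lower numbers stand for stronger inhibition and higher numbers for weaker inhibition:
- Compound 1 `Cc1ccc(S(=O)(=O)N2C(=O)C(C)OC23C=CC(=O)C=C3)cc1`: > 10000 nM (a limit)
- Compound 2 `O=C1C=CC2(C=C1)OCC(=O)N2S(=O)(=O)c1ccc(Cl)cc1`: > 10000 nM (a limit)
- Compound 3 `N#Cc1cccc(S(=O)(=O)N2C(=O)COC23C=CC(=O)C=C3)c1`: 180 nM

Compound 2 is known only as a limit, and it stands at the limit of > 10000 nM in this assay, at which 2 of the 3 values shown sit. Compound 4 `O=C1C=CC2(C=C1)OCC(=O)N2S(=O)(=O)c1ccc(OC(F)(F)F)cc1` is still to be measured in this assay. It carries trifluoromethoxy in place of chloro on an aromatic carbon, para to a large group: trifluoromethoxy in place of chloro on an aromatic carbon.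

For the measured compounds named here, no measured pair isolates a single change, and compound 2 offers no number to start from. Compound 3, at 180 nM, shows that a compound with the shared core can give a measurable value here, and this is the main support for expecting a number at all. The expected move is a modest one towards stronger inhibition, estimated as an at least 2.5-fold lower number from compound 2 to compound 4 (0.39 log units; beyond the scatter), with its size poorly defined. Another limit reading remains quite possible. For compound 4 the estimate is 4000 nM, with an expected range of 400 nM to 20000 nM.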

Compound 4, half-maximal inhibitory concentration: > 10000 nM
Compound 4 gave a limit, no number; the forecaster's own chance of this, stated with the estimate: 45%; at least 2.5-fold (0.39 log units) between middle value and limit.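

Compound 2 and compound 4 both rest at a limit, not a number, so no step between them can be read: the limit of > 10000 nM in this assay, at which 3 of the 4 values shown sit.

The compounds shown leave open how trifluoromethoxy compares with chloro, and whether compound 2 or compound 4 would reach a measurable value at all.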